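The compounds below may be only part of what the source reports. "The series", "measured", "known", "first", "only" and "open" are said of these compounds alone.

Measured so far:
compound 1 `COc1ccccc1C(=O)Nc1cccc(-c2oc3cc(-c4ccc(F)cc4)ccc3c(=O)c2O)c1` — 9050 nM
compound 2 `O=C(Nc1cccc(-c2oc3cc(-c4ccc(F)cc4)ccc3c(=O)c2O)c1)c1ccc(Br)cc1` — 8630 nM

In a functional assay on HCC1937 cells (Homo sapiens) for antiproliferative activity, read by CCK-8 assay, with a stated time of 72 h (on this read-out lower numbers stand for stronger inhibition and higher numbers for weaker inhibition), compound 1 gives 9050 nM and compound 2 gives 8630 nM. Compound 1 has the highest of the two numbers, but its nearest neighbour compound 2 lies within the scatter of it, so the two are not separable on this read-out. Compound 3 `CCc1ccc(C(=O)Nc2cccc(-c3oc4cc(-c5ccc(F)cc5)ccc4c(=O)c3O)c2)cc1` differs from compound 1 in one place: 4-ethylphenyl in place of 2-methoxyphenyl on a carbonyl carbon. Going by the values given here, the only measured step that bears on this change is the exchange of the aryl ring on the same carbonyl carbon, a 1.0-fold lower number from compound 1 to compound 2 (0.02 log units; within the scatter), which was flat. On that basis no step beyond the scatter is expected from compound 1 to compound 3 in this assay, in either direction. Compound 3 is therefore estimated at 9000 nM, with a range from 4500 nM to 18000 nM. This estimate means an expected 1.0-fold lower number from compound 1 to compound 3 (0.00 log units; within the scatter).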

Compound 3, half-maximal inhibitory concentration: 13200 nM
Compound 3: middle estimate off by 1.5-fold (0.17 log units), on the low side; low and high end bracket the measured number.
By their numbers in this assay, from the lowest: compounds 2, 1 and 3 (each within the scatter of the next).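

In this assay a third aryl group on this carbonyl carbon reads level with the other two: 4-ethylphenyl in place of 2-methoxyphenyl gives a 1.5-fold higher number from compound 1 to compound 3 (0.16 log units; within the scatter) and ethyl in place of bromo on an aromatic carbon gives a 1.5-fold higher number from compound 2 to compound 3 (0.18 log units; within the scatter) on the same read-out. The earlier pair held only groups carrying oxygen or bromo, whereas 4-ethylphenyl is made of carbon alone and still cannot be separated from either of them here. Nothing available explains why these three aryl groups read alike.

The compounds shown leave open whether any group on this carbonyl carbon can move the number beyond the scatter, in either direction, since all three carry a single substituted phenyl ring there. A basic amine, a carboxylic acid or a longer alkyl chain on that ring would test this.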